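Hex-5-en-1-yl for cyclopentyl, repeated on a shorter core

A few compounds are considered here, and "the series" means these few. Any claim that something is new, unique, unknown or untested is made for them only; others in the source may bear on it.

Compound 1 `C=CCCCCCCCS(=O)(=O)/C=C/c1ccc(O)c(O)c1`: 6900 nM
Compound 2 `O=S(=O)(/C=C/c1ccc(O)c(O)c1)CCCC1CCCC1`: 6300 nM
Compound 3 `O=S(=O)(/C=C/c1ccc(O)c(O)c1)CC1CCCC1`: 9400 nM

All three were measured in a functional assay, read by fluorescence and spectrophotometry, with a stated time of 1 h; a lower number here means that less compound is needed, a higher number that more compound is needed for the effect. Compound 2 and compound 3 differ in their cores by cyclopentyl in place of 2-cyclopentylethyl on a saturated chain carbon bound to a sulfonyl sulfur. Their values in this assay lie within the scatter of each other, as does the gap to compound 1, so no ordering among the three can be read from these numbers.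

The change from compound 2 to compound 1 is hex-5-en-1-yl in place of cyclopentyl on a saturated chain carbon, three bonds along the chain from a sulfonyl sulfur, and it made a 1.1-fold higher number from compound 2 to compound 1 (0.04 log units; within the scatter). The same kind of change is now applied to compound 3 to give compound 4 `C=CCCCCCS(=O)(=O)/C=C/c1ccc(O)c(O)c1`: hex-5-en-1-yl in place of cyclopentyl on a saturated chain carbon bound to a sulfonyl sulfur. The two cases differ in their surroundings: in compound 2 the exchange sits on a saturated chain carbon, three bonds along the chain from a sulfonyl sulfur, whereas in compound 3 it sits on a saturated chain carbon bound to a sulfonyl sulfur.

The step expected here is a 1.0-fold lower number from compound 3 to compound 4 (0.02 log units; within the scatter), resting on the earlier case since a 1.1-fold higher number from compound 2 to compound 1 (0.04 log units; within the scatter) stayed within the scatter. Compound 4 is estimated to give about 9000 nM in this assay, most likely between 4000 nM and 20000 nM.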

Compound 4, half-maximal effective concentration: 7100 nM
For compound 4 the middle estimate is 1.3-fold (0.10 log units) above the measured one, and the stated range covers the measured number.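

On the core of compound 3, hex-5-en-1-yl in place of cyclopentyl gave in this assay a 1.3-fold lower number from compound 3 to compound 4 (0.12 log units; within the scatter), and this step agrees with the earlier case on the other core: the same change on two cores in this assay, a 1.1-fold higher number (0.04 log units; within the scatter) from compound 2 to compound 1 and a 1.3-fold lower number (0.12 log units; within the scatter) from compound 3 to compound 4, 1.5-fold (0.16 log units) apart, within the scatter of two such steps The remaining steps, a 1.1-fold higher number from compound 2 to compound 4 (0.05 log units; within the scatter) and a 1.0-fold higher number from compound 1 to compound 4 (0.01 log units; within the scatter), also stay within the scatter, so compound 4 cannot be ordered against compound 1 or compound 2. The two cores therefore agree in that the exchange left no readable mark on either, but this does not show that an effect of a given size carries from one core to the other, as neither step holds such an effect.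

Still open, as far as these compounds go, is whether any group on a saturated chain carbon bound to a sulfonyl sulfur would give a step beyond the scatter, for example an amine, a carboxylic acid or a much longer chain. Also open, from the compounds shown here alone, is whether the agreement between the two cores would hold for such a group.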